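Hydroxycyclohexyl in Place of Methoxycyclohexyl: Expected Half-Life

The source may hold more compounds than are shown below. What is called first, only, known or untested is meant among the compounds shown, and "the series" means these compounds.

The series shares one core, carried by compound 2 `CO[C@H]1CC[C@H](n2nc(Oc3cc(C(F)(F)F)ccn3)c3c(N)ncnc32)CC1`, compound 1 `Nc1ncnc2c1c(Oc1cccc(C(F)(F)F)c1)nn2[C@H]1C[C@H](O)C1`, compound 3 `Nc1ncnc2c1c(Oc1cc(Cl)ccn1)nn2C1CCC1` and the still unmeasured compound 4 `Nc1ncnc2c1c(Oc1cc(C(F)(F)F)ccn1)nn2[C@@H]1CCCC[C@H]1O`. In an ADME assay on microsomes from liver (Homo sapiens) for metabolic stability, read by LC-MS, using NADPH, with a stated time of 10 min, tested at 10 uM (on this read-out lower numbers stand for a shorter-lived compound and higher numbers for a longer-lived compound), compound 1 gives 1.25 h, and compound 3 gives 0.333 h. For compound 2 the read-out is only a limit of the assay, > 2.41 h, so compound 2 stands at the limit of > 2.41 h in this assay, at which 1 of the 3 values shown sits. The change from compound 2 to compound 4 is 2-hydroxycyclohexyl in place of 4-methoxycyclohexyl on an aromatic nitrogen. Within the data shown here, no measured pair isolates this change, so its direction is open from the data alone. A step back from the limit, beyond the scatter, is nevertheless expected: an at least 1.7-fold lower number from compound 2 to compound 4 (0.23 log units; that floor lies within the scatter). Compound 4 is estimated at 1.4 h, in a range from 0.6 h to 2.41 h.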

Compound 4, half-life: > 2.41 h
Compound 4 ended at the assay's limit; the forecaster's own chance of this, stated with the estimate: 30%; at least 1.7-fold (0.23 log units) between middle value and limit.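

No step can be read between compound 2 and compound 4, as both sit at the same limit of the assay: the limit of > 2.41 h in this assay, at which 2 of the 4 values shown sit.

The compounds shown leave open whether 2-hydroxycyclohexyl in place of 4-methoxycyclohexyl changes the half-life at all, and in which direction.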